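Alpha-2C series: methylsulfonyl in place of methoxy

The compounds below may be only part of what the source reports. "The series", "measured", "known", "first", "only" and "open" are said of these compounds alone.

Measured so far:
compound 1 `CCc1ccccc1OC(C)C1=NCCN1` gives 288 nM in an assay on CHO cells for displacement of a labelled ligand from Alpha-2C adrenergic receptor (Homo sapiens); a higher number here means a weaker inhibitor, a lower number a stronger inhibitor
compound 2 `COc1ccccc1OC(C)C1=NCCN1` gives 832 nM in this assay

Within the data shown here, compound 2 stands at the higher of the two numbers in this assay; its only neighbour is compound 1, and the step of a 2.9-fold higher number from compound 1 to compound 2 (0.46 log units; beyond the scatter) is the single measured step.

Compound 3 `CC(Oc1ccccc1S(C)(=O)=O)C1=NCCN1` is not yet measured. It differs from compound 2 in one place: methylsulfonyl in place of methoxy on an aromatic carbon. Among the measured compounds shown here, the one measured step, a 2.9-fold higher number from compound 1 to compound 2 (0.46 log units; beyond the scatter), concerns a different replacement at the same aromatic carbon; it shows only that the number responds to the group there, and no measured step involves methylsulfonyl. A further modest rise in the number is therefore expected, a 2.4-fold higher number from compound 2 to compound 3 (0.38 log units; beyond the scatter), with wide uncertainty in both directions. For compound 3 the expected value in this assay is 2000 nM, with a range from 600 nM to 7000 nM.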

Compound 3, inhibition constant: 3800 nM
Estimate against measurement, compound 3: 1.9-fold (0.28 log units) below; low and high end bracket the measured number.
By their numbers in this assay, from the lowest: compound 1; then compound 2; then compound 3.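

In this assay, the same aromatic carbon now carries three groups, and the numbers rise in the order ethyl, methoxy, methylsulfonyl, with every step between them beyond the usual scatter. Methylsulfonyl gives a 4.6-fold higher number from compound 2 to compound 3 (0.66 log units; beyond the scatter), and set against ethyl it gives a 13-fold higher number from compound 1 to compound 3 (1.12 log units; beyond the scatter), the first large step in the series, which makes compound 3 the weakest inhibitor of the three. Nothing available bears on why the number rises with this replacement.

As far as these compounds go, three groups at one carbon do not define a trend, so it remains open whether a longer chain such as propyl, a halogen such as chlorine or an amine there would continue this order or break it. Also open, from the compounds shown here alone, is whether methylsulfonyl has the same effect at other carbons of the aromatic ring or on a changed core.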